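Trihydroxyphenyl to methoxyphenyl: an expected loss of inhibition

The compounds below may be only part of what the source reports. "The series", "measured", "known", "first", "only" and "open" are said of these compounds alone.

In a physicochemical assay, read by spectrophotometry, with a stated time of 30 min (a higher number here means a weaker inhibitor, a lower number a stronger inhibitor), compound 1 `O=C(CCc1nc2ccccc2c(=O)[nH]1)N/N=C/c1ccc(O)c(O)c1` gives 113000000 nM, compound 2 `O=C(CCc1nc2ccccc2c(=O)[nH]1)N/N=C/c1ccc(O)cc1` gives 238000000 nM and compound 3 `O=C(CCCc1nc2ccccc2c(=O)[nH]1)N/N=C/c1cc(O)c(O)c(O)c1` gives 78000000 nM. Compound 3 thus lies within the scatter of compound 1, while compound 2 shows the higher number, beyond the scatter. Compound 4 `COc1ccc(/C=N/NC(=O)CCCc2nc3ccccc3c(=O)[nH]2)cc1` has 4-methoxyphenyl in place of 3,4,5-trihydroxyphenyl on a carbon with a double bond to nitrogen. Among the compounds with values here, one measured step bears on this change: a 2.1-fold higher number from compound 1 to compound 2 (0.32 log units; beyond the scatter), a modest step between two compounds whose chain differs from that of compound 3. Compound 4 keeps no hydroxy group, so on the strength of a 2.1-fold higher number from compound 1 to compound 2 (0.32 log units; beyond the scatter) a similar or somewhat larger move towards weaker inhibition is expected in this assay. The expected change is a 2.9-fold higher number from compound 3 to compound 4 (0.47 log units; beyond the scatter). The estimate for compound 4 is 230000000 nM, with an expected range of 100000000 nM to 520000000 nM.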

Compound 4, half-maximal inhibitory concentration: 247000000 nM
Beside the measured number, compound 4's estimate is 1.1-fold (0.03 log units) below it; measured number inside the range.
By their numbers in this assay, from the lowest: compounds 3 and 1 (each within the scatter of the next); then compounds 2 and 4 (each within the scatter of the next).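

In this assay, the change to 4-methoxyphenyl on a carbon with a double bond to nitrogen gives a 3.2-fold higher number from compound 3 to compound 4 (0.50 log units; beyond the scatter), so this position also responds on the chain of compound 3, where all three hydroxy groups leave and one methoxy enters. The direction matches a 2.1-fold higher number from compound 1 to compound 2 (0.32 log units; beyond the scatter), which involved one hydroxy group on a different chain. No supporting measurement accounts for either step.

The contributions of losing the hydroxy groups and gaining the methoxy cannot be separated here. As far as these compounds go, it also remains open how 4-hydroxyphenyl on the chain of compound 3, or an amine or a carboxylic acid on its aromatic ring, would read.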